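Varying the aryl group on the sulfonyl of a shared core

The compounds below may be only part of what the source reports. "The series", "measured", "known", "first", "only" and "open" are said of these compounds alone.

Compound 1 `COc1cccc(S(=O)(=O)c2cnc3cc(Cl)ccc3c2N2CCC(C)CC2)c1`: 93%
Compound 2 `Cc1ccc(S(=O)(=O)c2cnc3cc(Cl)ccc3c2N2CCC(C)CC2)cc1C`: 86%

Two measured compounds share one core and differ only in the aryl group carried by the sulfonyl sulfur. In an assay on isolated protein for displacement of a labelled ligand from metabotropic glutamate receptor 5 (Homo sapiens), with a stated time of 60 min, tested at 1 uM (on this read-out lower numbers stand for less inhibition and higher numbers for more inhibition at the one concentration tested (going by the name of the read-out)), compound 1 gives 93%. In this assay compound 2 gives 86%. Among the measured compounds shown here, compound 2 sits at one end of this pair of numbers, but the only step so far, a number 7 percentage points lower from compound 1 to compound 2 (within the scatter), lies within the scatter, so the two compounds cannot be told apart on these data.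

Compound 3 `COc1ccc(S(=O)(=O)c2cnc3cc(Cl)ccc3c2N2CCC(C)CC2)cc1` is not yet measured. It differs from compound 2 in exactly this place: 4-methoxyphenyl in place of 3,4-dimethylphenyl on a sulfonyl sulfur. For the measured compounds named here, the one measured step that bears on an exchange of the aryl group on the sulfonyl sulfur is a number 7 percentage points lower from compound 1 to compound 2 (within the scatter), and it stayed within the scatter. With nothing else to go on, the expectation for compound 3 is another change no larger than the scatter, so the step of a number 3 percentage points higher from compound 2 to compound 3 (within the scatter) is estimated to be small. Compound 3 is therefore expected to give about 89% in this assay, with a likely range from 76% to 97%.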

Compound 3, a percentage reported as inhibition, at one concentration (the size of the read-out at that concentration, not a potency): 79%
Compound 3: the middle estimate sits 10 percentage points above what was measured; the measured number falls inside the stated range.
By their numbers in this assay, from the lowest: compounds 3, 2 and 1 (each within the scatter of the next, the first and the last beyond it).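

In this assay, among the compounds shown here, the exchange of 3-methoxyphenyl for 4-methoxyphenyl on the sulfonyl sulfur gives a number 14 percentage points lower from compound 1 to compound 3 (beyond the scatter) and is the first step at this position that stands out from the noise of repeat measurements. The two groups are built from the same atoms and differ only in the number in their names, so the place of the methoxy on the ring, and not just its presence, can show up in this read-out. The other exchange, which gives a number 7 percentage points lower from compound 2 to compound 3 (within the scatter) when 4-methoxyphenyl replaces 3,4-dimethylphenyl, does not separate its two compounds, and compound 2 remains within the scatter of both neighbours, so only the two methoxy compounds can be told apart.

Nothing available explains why moving the methoxy group changes the reading. Still open, going by these compounds, is how this position responds to a ring carrying an amine or a carboxylic acid, or to a longer chain such as ethoxy in place of methoxy, and whether the gap between the two methoxy compounds would persist as a difference in potency, which a reading at one concentration cannot show.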